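Swapping the amide heteroaryl ring on a dimethylamino analogue

The compounds below may be only part of what the source reports. "The series", "measured", "known", "first", "only" and "open" are said of these compounds alone.

Of the compounds shown here, two from this series have been measured in a functional assay on A549 cells (Homo sapiens) for antiproliferative activity, read by MTT assay, with a stated time of 72 h; on this read-out higher numbers stand for weaker inhibition and lower numbers for stronger inhibition. Compound 1 `COc1cc(F)c(NC(=O)c2nccn2C)cc1Nc1nccc(-c2cn(C)c3ccccc23)n1` gives 5140 nM in this assay. Compound 2 `COc1cc(N(C)C)c(NC(=O)c2ncccn2)cc1Nc1nccc(-c2cn(C)c3ccccc23)n1` gives 8640 nM in this assay, the higher of the two numbers, though the gap to compound 1 lies within the scatter, so the two values show no real difference. Compound 1 and compound 2 differ in two places, so no single change can be read from them.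

Compound 3 `COc1cc(N(C)C)c(NC(=O)c2nccn2C)cc1Nc1nccc(-c2cn(C)c3ccccc23)n1` is not yet measured. It differs from compound 2 in one place: 1-methyl-1H-imidazol-2-yl in place of pyrimidin-2-yl on a carbonyl carbon. Going by the values given here, no measured pair in this set shows the effect of this change alone. Compound 1, which carries the same 1-methyl-1H-imidazol-2-yl group, gave 5140 nM in this assay, and on that thin basis compound 3 is expected to land at about 5500 nM in this assay, within roughly 2000 nM to 15000 nM. The step from compound 2 to compound 3 is thus estimated as a 1.6-fold lower number from compound 2 to compound 3 (0.20 log units; within the scatter), a change not clearly beyond the scatter.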

Compound 3, half-maximal inhibitory concentration: 10200 nM
The estimate for compound 3 lay 1.9-fold (0.27 log units) below the measured number; the range from low to high includes it.
By their numbers in this assay, from the lowest: compounds 1, 2 and 3 (each within the scatter of the next).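

In this assay, 1-methyl-1H-imidazol-2-yl in place of pyrimidin-2-yl on a carbonyl carbon gives a 1.2-fold higher number from compound 2 to compound 3 (0.07 log units; within the scatter), so with dimethylamino held constant, this exchange of rings has no measurable effect. The series now also has a single-change reading at the other site, where dimethylamino in place of fluoro on an aromatic carbon gives a 2.0-fold higher number from compound 1 to compound 3 (0.30 log units; within the scatter), and this step also stays within the usual scatter of repeated measurements. No supporting data bear on these two results.

Neither site has yet been shown to influence the number in this assay. On these data alone, it remains open whether a phenyl ring or a saturated amine such as piperidine on the carbonyl carbon, or a chlorine atom or a methoxy group on the aromatic carbon, would produce a step beyond the scatter.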